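The compounds below may be only part of what the source reports. "The series", "measured", "known", "first", "only" and "open" are said of these compounds alone.

Series notes. Compound 1 `O=C1CC(N2CCN(c3ccc(O)cc3)CC2)C(=O)N1c1ccccc1` and compound 2 `O=C1CC(N2CCN(c3ccc(O)cc3)CC2)C(=O)N1Cc1ccccc1` share one core and differ only at the amide-type nitrogen in the ring. In an assay on isolated protein for inhibition of NADP-dependent malic enzyme (Homo sapiens) (a higher number here means a weaker inhibitor, a lower number a stronger inhibitor), compound 1 gives 150 nM, and in the same assay compound 2 gives 450 nM. Within the data shown here, the single measured step, a 3.0-fold higher number from compound 1 to compound 2 (0.48 log units; beyond the scatter), is the only comparison so far, so compound 2 stands as the higher of the two numbers, with compound 1 as its nearest neighbour at a lower value.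

Compound 3 `O=C1CC(N2CCN(c3cccc(O)c3)CC2)C(=O)N1Cc1ccccc1` is the next member. Against compound 2 the difference is 3-hydroxyphenyl in place of 4-hydroxyphenyl on an amine nitrogen in a ring; it is a shift of the hydroxyl around the ring, with all atoms retained. Among the measured compounds shown here, no measured step touches this part of the molecule: the step from compound 1 to compound 2 concerns the amide-type nitrogen and gives no guide to a change on the amine nitrogen side. The expectation for compound 3 in this assay is therefore held loosely, with a step of a 1.3-fold higher number from compound 2 to compound 3 (0.12 log units; within the scatter) expected as the working guess. On that basis compound 3 is estimated at 600 nM, within a range of 200 nM to 2000 nM.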

Compound 3, half-maximal inhibitory concentration: 10000 nM
Beside the measured number, compound 3's estimate is 17-fold (1.22 log units) below it; the whole stated range lies below it.
By their numbers in this assay, from the lowest: compound 1; then compound 2; then compound 3.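

Among these compounds, the location of the hydroxyl on the aryl group carried by the amine nitrogen in a ring matters far more in this assay than the one change seen before: 3-hydroxyphenyl in place of 4-hydroxyphenyl, with the same atoms, gives a 22-fold higher number from compound 2 to compound 3 (1.35 log units; beyond the scatter) and is printed as large, whereas a 3.0-fold higher number from compound 1 to compound 2 (0.48 log units; beyond the scatter) at the amide-type nitrogen is printed as modest. This position therefore responds to how the atoms are arranged, not only to which atoms are present, and of the two arrangements shown, 4-hydroxyphenyl goes with the lower number. Nothing at hand accounts for the size of this step.

From the compounds shown here alone, whether the hydroxyl itself is needed remains open, and a methoxy group, an amine or a plain phenyl at this position would separate the part played by the group from the part played by its location. Also open, going by these compounds, is whether the same gap between 3-hydroxyphenyl and 4-hydroxyphenyl would appear with the phenyl of compound 1 on the amide-type nitrogen in place of the benzyl shared by compound 2 and compound 3.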